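The source may report more compounds than this note shows. Statements on the series, on what has been measured and on what is new or still open speak of the compounds shown alone.

Measured so far:
- compound 1 `O=C(O)[C@H]1CC[C@@H](Oc2ccc3oc(-c4ccccc4)nc3c2)CC1` — 4400 nM
- compound 2 `Cc1cccc(Cc2nc3cc(O[C@H]4CC[C@@H](C(=O)O)CC4)ccc3n2C)c1` — 42 nM
- compound 3 `Cc1cccc(Cc2c(C#N)c3cc(O[C@H]4CC[C@@H](C(=O)O)CC4)ccc3n2C)c1` — 1900 nM

All three numbers come from an assay on isolated protein for inhibition of Long-chain-fatty-acid--CoA ligase 1 (Homo sapiens), read by mass spectrometry, with a stated time of 90 min, in the presence of a further agent that is not named here; a lower number here means a stronger inhibitor, a higher number a weaker inhibitor. Compound 2 stands lowest of the three; compound 3 is its nearest neighbour and compound 1 the furthest, both beyond the scatter, so compound 2 is the strongest inhibitor of the set in this assay.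

Compound 4 `Cc1cccc(C(=O)c2nc3cc(O[C@H]4CC[C@@H](C(=O)O)CC4)ccc3n2C)c1` is not yet measured. It differs from compound 2 by (3-methylphenyl)carbonyl in place of 3-methylbenzyl on an aromatic carbon. Among the compounds with values here, no measured pair shows this change, so no step can be drawn from the data. The shown series does indicate that this region is sensitive: compound 2 gives 42 nM, while compound 3, which differs from it only near the same carbon, gives 1900 nM. A loss is therefore expected for compound 4, of size a 9.5-fold higher number from compound 2 to compound 4 (0.98 log units; beyond the scatter). Compound 4 is estimated at 400 nM, range 80 nM to 2500 nM.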

Compound 4, half-maximal inhibitory concentration: > 200000 nM
Compound 4: only a limit was reported; the forecaster's own chance of this, stated with the estimate: 5%; middle value at least 500-fold (2.69 log units) from the limit.
By their numbers in this assay, from the lowest: compound 2; then compound 3; then compound 1. At a limit, above all of these: compound 4.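

In this assay compound 4 reads > 200000 nM, a limit of the assay and not a number. Replacing 3-methylbenzyl with (3-methylphenyl)carbonyl on the aromatic carbon between two ring nitrogen atoms gives an at least 4700-fold higher number from compound 2 to compound 4 (3.67 log units; beyond the scatter). Within the data shown here, this is the first one-place change measured at this carbon, and it shows that the carbonyl link cannot stand in for the benzyl methylene.

Going by these compounds, whether the loss is specific to the carbonyl remains open. An ether oxygen or an amine as the link could still retain inhibition.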